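Aryl change at the saturated ring carbon, compound 3

A few compounds are considered here, and "the series" means these few. Any claim that something is new, unique, unknown or untested is made for them only; others in the source may bear on it.

Working notes. Within the data shown here, compound 2 `COc1cc(C2=NN(C(C)=O)C(c3ccc(F)c(F)c3)O2)cc(OC)c1OC` gives 21.6% in a functional assay on BGC-823 cells (Homo sapiens) for antiproliferative activity, read by MTT assay, tested at 5 uM (on this read-out lower numbers stand for a weaker effect and higher numbers for a stronger effect at the one concentration tested), the lowest of the two numbers so far; compound 1 `COc1cc(C2=NN(C(C)=O)C(c3ccccc3C(F)(F)F)O2)cc(OC)c1OC` gives 34.8% in this assay. Compound 3 `COc1cc(C2=NN(C(C)=O)C(c3cccc(C(F)(F)F)c3)O2)cc(OC)c1OC` differs from compound 2 as 3-(trifluoromethyl)phenyl in place of 3,4-difluorophenyl on a saturated ring carbon, the new group again sitting on a saturated ring carbon of the five-membered non-aromatic ring. Among the measured compounds shown here, the one measured step that bears on it is a number 13.2 percentage points lower from compound 1 to compound 2 (beyond the scatter), in which 3,4-difluorophenyl took the place of 2-(trifluoromethyl)phenyl. Compound 3 brings a trifluoromethylphenyl back, so a modest rise is expected, a number 8.4 percentage points higher from compound 2 to compound 3 (within the scatter). Compound 3 is expected to give 30% in this assay, between 16% and 44%.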

Compound 3, a percentage reported as inhibition, at one concentration (the size of the read-out at that concentration, not a potency): 41.1%
Estimate against measurement, compound 3: 11.1 percentage points below; the range from low to high includes it.
By their numbers in this assay, from the lowest: compound 2; then compounds 1 and 3 (each within the scatter of the next).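

In this assay the step of a number 19.5 percentage points higher from compound 2 to compound 3 (beyond the scatter) shows that this saturated ring carbon responds to the choice of aryl group, and a single trifluoromethyl group carries more of the read-out here than the two fluorines of 3,4-difluorophenyl. The step of a number 6.3 percentage points higher from compound 1 to compound 3 (within the scatter) means that 2-(trifluoromethyl)phenyl and 3-(trifluoromethyl)phenyl cannot be told apart in this series. No measurement available here accounts for either step.

As far as these compounds go, whether a phenyl ring bearing an amine or a carboxylic acid at this carbon would keep the read-out stays open. So does whether the stronger and weaker effects seen at this one concentration would hold at any other concentration.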